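The compounds below may be only part of what the source reports. "The series", "measured", "known", "first", "only" and "open" are said of these compounds alone.

Measured so far in an assay on isolated protein for inhibition of ATP-dependent RNA helicase DDX3X (Homo sapiens), read by FRET, with a stated time of 40 min; a lower number here means a stronger inhibitor, a higher number a weaker inhibitor:

- compound 1, `CCCCc1nnc(-c2ccc(NC(=O)Nc3ccccc3C(F)(F)F)cc2)o1`: 1000 nM
- compound 2, `CCCCc1nc(-c2ccc(NC(=O)Nc3ccccc3C(F)(F)F)cc2)n[nH]1`: 70 nM

Within the data shown here, compound 2 holds the lower of the two numbers; its only neighbour is compound 1, and the step of a 14-fold lower number from compound 1 to compound 2 (1.15 log units; beyond the scatter) separates them. Among the measured compounds shown here, that step is the one comparison available for the series: it exchanges the five-membered ring on the shared core while everything else is kept.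

Compound 3, `CCCCn1nnc(-c2ccc(NC(=O)Nc3ccccc3C(F)(F)F)cc2)n1`, is not yet measured. It differs from compound 2 by 2-butyl-2H-tetrazol-5-yl in place of 5-butyl-1H-1,2,4-triazol-3-yl on an aromatic carbon. Like the ring of compound 1, the entering ring carries no hydrogen-bond donor, so compound 3 sits structurally between the two measured cases rather than extending from compound 2. For the measured compounds named here, the only step that bears on it is a 14-fold lower number from compound 1 to compound 2 (1.15 log units; beyond the scatter), which was large. Going by the values given here, the expectation is a step back toward compound 1, because compound 1 gives 1000 nM with a donor-free ring in the same position; the size is uncertain, as the butyl chain now sits on a ring nitrogen, a change no measured pair covers. The expected step is a 7.1-fold higher number from compound 2 to compound 3 (0.85 log units; beyond the scatter). Compound 3 is therefore estimated at 500 nM, in the range 150 nM to 2000 nM.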

Compound 3, half-maximal inhibitory concentration: 800 nM
For compound 3 the middle estimate is 1.6-fold (0.20 log units) below the measured one; the range from low to high includes it.
By their numbers in this assay, from the lowest: compound 2; then compounds 3 and 1 (each within the scatter of the next).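

In this assay, exchanging the 5-butyl-1H-1,2,4-triazol-3-yl group for 2-butyl-2H-tetrazol-5-yl on the shared core gives an 11-fold higher number from compound 2 to compound 3 (1.06 log units; beyond the scatter), so the low number of compound 2 does not carry over to this other five-membered aromatic ring. Against the 5-butyl-1,3,4-oxadiazol-2-yl group, the same tetrazole gives a 1.3-fold lower number from compound 1 to compound 3 (0.10 log units; within the scatter), so these two rings cannot be told apart here, even though the butyl chain is attached to a ring nitrogen in compound 3. Among these three compounds, the low number goes with the only ring that has 1 hydrogen-bond donor, while both rings with 0 hydrogen-bond donors give high numbers and none of the three goes against this, but the pattern rests on compound 2 alone and no supporting data bear on the reason for it.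

Going by these compounds, it remains open whether the ring hydrogen of compound 2 is itself what matters, which a methyl group on that triazole nitrogen would test. On these data alone, it is also open how the triazole responds to a change of chain, such as a propyl or hexyl group in place of butyl.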